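The source may hold more compounds than are shown below. What is called first, only, known or untested is meant among the compounds shown, and "the series" means these compounds.

Four compounds share one core, and they differ in the two groups attached to it. Compound 1 `CCCCNc1oc2c(C)ncc(CO)c2c1Nc1ccccn1` carries a butylamino group and a pyridinylamino group; in a functional assay on HEK293 cells for agonist activity at Toll-like receptor 8 (Homo sapiens), read by reporter gene assay (a lower number here means that less compound is needed, a higher number that more compound is needed for the effect), compound 1 gives 9380 nM. Compound 2 `Cc1ncc(CO)c2c(Nc3ccccc3)c(NCc3ccccc3)oc12` carries a benzylamino group and a phenylamino group, and in this assay compound 2 gives 1680 nM. Among the compounds with values here, compound 3 `Cc1ncc(CO)c2c(Nc3ccccn3)c(N)oc12` carries the pyridinylamino group and a plain amino group; in this assay compound 3 gives "not active" (no number reported), with no number to set against the other two, so it stands as the one compound here without a place on the scale. Compound 4 `Cc1ncc(CO)c2c(Nc3ccccn3)c(NCc3ccccc3)oc12` differs from compound 3 in one place: benzyl in place of hydrogen on a nitrogen on an aromatic ring. Within the data shown here, no measured pair shows this change on its own. Still, compound 2, which already carries the benzylamino group, gives 1680 nM, while compound 1, which carries a butylamino group in that place, gives 9380 nM; both are numbers where compound 3 has none. Compound 4 is therefore expected to move from inactive into the measurable range, and the estimate for compound 4 in this assay is 3000 nM, within a range from 700 nM to 15000 nM.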

Compound 4, half-maximal effective concentration: 4910 nM
For compound 4 the middle estimate is 1.6-fold (0.21 log units) below the measured one; measured number inside the range.
By their numbers in this assay, from the lowest: compound 2; then compounds 4 and 1 (each within the scatter of the next).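

Compound 4 shows that putting benzyl on this nitrogen on an aromatic ring gives a compound with a place on the scale: in this assay compound 4 gives 4910 nM as a measured number, whereas compound 3, with the plain amino group, has none. The pyridin-2-yl group also counts for something here, since with benzylamino held constant, replacing phenyl with it gives a 2.9-fold higher number from compound 2 to compound 4 (0.47 log units; beyond the scatter) as a modest step beyond the scatter. By contrast, with pyridin-2-yl held constant, the change from butylamino to benzylamino gives a 1.9-fold lower number from compound 1 to compound 4 (0.28 log units; within the scatter) and stays within the scatter, so these two groups cannot be told apart in this assay on this evidence.

Nothing shown explains why any of these numbers differ. Open questions are whether a shorter chain such as ethyl, a longer chain such as hexyl, or a cyclohexylmethyl group on this nitrogen would give a number in the same range, and whether pyridin-3-yl in place of pyridin-2-yl would behave like phenyl.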